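This account rests on a few compounds, and the source may have more. Where it says the series, first, only, none or still open, it means among the compounds named here.

In a functional assay on HeLa cells (Homo sapiens) for antiproliferative activity (on this read-out higher numbers stand for weaker inhibition and lower numbers for stronger inhibition), compound 1 (`CCONC(=O)c1sc(N2N=C(c3ccc(C)cc3)CC2c2cc3cc(OC)ccc3nc2Cl)nc1C`) gives 38 nM. Compound 2 (`Cc1ccc(Nc2nnc(-c3cc(-c4ccc(Br)cc4)nc4ccccc34)o2)cc1`), which is built on a different core, gives 50 nM. These two numbers lie within the usual scatter of each other, so compound 1 stands level with compound 2 and the data give no order for them.

The step of interest leads to compound 3 (`COc1ccc2nc(Cl)c(C3CC(c4ccc(C)cc4)=NN3c3nc(-c4ccc(C)cc4)cs3)cc2c1`), which keeps the core of compound 1 and changes one group: 4-(4-methylphenyl)-1,3-thiazol-2-yl in place of 5-(ethoxycarbamoyl)-4-methyl-1,3-thiazol-2-yl on an amine nitrogen in a ring. Put simply, 4-(4-methylphenyl)-1,3-thiazol-2-yl takes the place of 5-(ethoxycarbamoyl)-4-methyl-1,3-thiazol-2-yl on an amine nitrogen in a ring. For the measured compounds named here, no measured pair here shows a swap of this kind, so any expectation remains loose and the range must be wide. A moderate move towards a higher number in this assay, which would mean weaker inhibition, is expected, and this estimated change is a 2.4-fold higher number from compound 1 to compound 3 (0.37 log units; beyond the scatter). Compound 3 is estimated at 90 nM, with an expected range from 25 nM to 350 nM.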

Compound 3, half-maximal inhibitory concentration: 38 nM
Compound 3: middle estimate off by 2.4-fold (0.37 log units), on the high side; the measured number falls inside the stated range.
By their numbers in this assay, from the lowest: compounds 1, 3 and 2 (each within the scatter of the next).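

In this assay, for the compounds shown here, putting 4-(4-methylphenyl)-1,3-thiazol-2-yl in place of 5-(ethoxycarbamoyl)-4-methyl-1,3-thiazol-2-yl on the amine nitrogen in the five-membered ring gives no change at the digits printed from compound 1 to compound 3 (within the scatter), the first reading of a change at this place on the core of compound 1. For this one pair, the ethoxycarbamoyl group, with its hydrogen-bond donor, is therefore not needed to keep the number at this level: the entering group has no hydrogen-bond donor and fewer hydrogen-bond acceptors, and it adds a six-membered aromatic ring of carbon only, with the same count of heavy atoms. Nothing measured here explains why the number holds across so large a change in the group.

The swap alters several parts of the group at once, so the effects of removing the ethoxycarbamoyl group, moving the methyl and adding the 4-methylphenyl group cannot be told apart. On these data alone, it also remains open whether a plain 1,3-thiazol-2-yl, or a thiazole carrying a carboxylic acid or an amine, would keep the number at this level.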